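Swapping the ring substituent on a piperazine-linked benzamide

A few compounds are considered here, and "the series" means these few. Any claim that something is new, unique, unknown or untested is made for them only; others in the source may bear on it.

Of the compounds shown here, three sharing one core have been tested in a functional assay on HeLa cells (Homo sapiens) for antiproliferative activity, read by CCK-8 assay, with a stated time of 72 h, tested at 2 uM; on this read-out higher numbers stand for a stronger effect at the one concentration tested and lower numbers for a weaker effect. Compound 1 `Nc1ccccc1NC(=O)c1ccc(CSC(=S)N2CCN(Cc3ccccn3)CC2)cc1` gives 14.2%. Compound 2 `Nc1ccccc1NC(=O)c1ccc(CSC(=S)N2CCN(c3ccc(Cl)cc3)CC2)cc1` gives 51.2%. Compound 3 `Nc1ccccc1NC(=O)c1ccc(CSC(=S)N2CCN(C3CCCCC3)CC2)cc1` gives 30.6%, which places it second highest of the three: compound 1 lies beyond the scatter below it and compound 2 beyond the scatter above it. The steps among them are a number 37 percentage points higher from compound 1 to compound 2 (beyond the scatter), a number 16.4 percentage points higher from compound 1 to compound 3 (beyond the scatter) and a number 20.6 percentage points lower from compound 2 to compound 3 (beyond the scatter).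

Compound 4 `Nc1ccccc1NC(=O)c1ccc(CSC(=S)N2CCN(Cc3ccncc3)CC2)cc1` has not yet been measured. It differs from compound 3 in one place: (pyridin-4-yl)methyl in place of cyclohexyl on an amine nitrogen in a ring. The change most closely related to this one is the move from compound 1 to compound 3, where the group now leaving entered and a (pyridin-2-yl)methyl group left, giving a number 16.4 percentage points higher from compound 1 to compound 3 (beyond the scatter). Compound 4 carries a (pyridin-4-yl)methyl group instead, which is close in kind to the group on compound 1, so a drop of modest size is expected in this assay, roughly reversing that earlier gain and bringing compound 4 near the level of compound 1. The expected step is a number 12.6 percentage points lower from compound 3 to compound 4 (beyond the scatter). Compound 4 is therefore estimated at 18%, with a likely range from 8% to 32%.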

Compound 4, a percentage reported as inhibition, at one concentration (the size of the read-out at that concentration, not a potency): 59.5%
Estimate against measurement, compound 4: 41.5 percentage points below; measured number outside the range, above it.
By their numbers in this assay, from the lowest: compound 1; then compound 3; then compounds 2 and 4 (each within the scatter of the next).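

In this assay, among these compounds, putting pyridin-4-yl in place of pyridin-2-yl on the saturated chain carbon gives a number 45.3 percentage points higher from compound 1 to compound 4 (beyond the scatter) and so shows that two closely named groups need not behave alike at this position: the point at which the aromatic ring is attached to its chain carbon, relative to its ring nitrogen, is the only thing that changes. The (pyridin-4-yl)methyl group also gives a number 28.9 percentage points higher from compound 3 to compound 4 (beyond the scatter) against cyclohexyl, and against 4-chlorophenyl it gives a number 8.3 percentage points higher from compound 2 to compound 4 (within the scatter), so among these compounds a (pyridinyl)methyl group does not by itself mean a low number, with compound 1 the one low case. Nothing measured here explains why the two pyridine-bearing groups part so widely.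

Still open, from the compounds shown here alone, is where (pyridin-3-yl)methyl would fall, and whether a plain benzyl group, with no ring nitrogen, would sit nearer compound 1 or compound 4. The read-out also comes from a single concentration, so it shows the size of the effect at that concentration and gives no potency for any of these compounds.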